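Bis-furan amidines: methoxy in place of fluoro

The source may hold more compounds than are shown below. What is called first, only, known or untested is meant among the compounds shown, and "the series" means these compounds.

Going by the values given here, compound 1 `N=C(N)c1ccc(-c2ccc(-c3ccc(F)cc3)o2)o1` gives 1900 nM in a functional assay on A498 cells (Homo sapiens) for inhibition, read by sulforhodamine B assay, with a stated time of 48 h (a lower number here means a stronger inhibitor of growth, a higher number a weaker inhibitor of growth), and is one of only two compounds measured. Compound 2 `N=C(N)c1ccc(-c2ccc(-c3ccc4ccccc4c3)s2)s1` gives 1700 nM in this assay, and the two numbers sit within the scatter of each other, so neither stands apart. Compound 3 `COc1ccc(-c2ccc(-c3ccc(C(=N)N)o3)o2)cc1` differs from compound 1 by methoxy in place of fluoro on an aromatic carbon. Among the compounds with values here, no measured pair covers this change, so a shift no larger than the scatter is expected in either direction, as a 1.2-fold lower number from compound 1 to compound 3 (0.07 log units; within the scatter). Compound 3 is estimated at 1600 nM in this assay, with a range from 600 nM to 4500 nM.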

Compound 3, concentration for 50% growth inhibition: 1760 nM
Estimate against measurement, compound 3: 1.1-fold (0.04 log units) below, within the range that was stated.
By their numbers in this assay, from the lowest: compounds 2, 3 and 1 (each within the scatter of the next).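

In this assay, going by these compounds alone, the step of a 1.1-fold lower number from compound 1 to compound 3 (0.03 log units; within the scatter) gives a first reading at this position, on an aromatic carbon para to a large group. Methoxy and fluoro are not told apart here, so on the core of compound 1 this position tolerates the larger group with no shift beyond the scatter. Nothing at hand bears on why the number holds. As far as these compounds go, whether an amine or a carboxylic acid at this position would also stay within the scatter remains open. This single step says nothing about other positions on the core.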